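A few compounds are considered here, and "the series" means these few. Any claim that something is new, unique, unknown or untested is made for them only; others in the source may bear on it.

Measured so far in a functional assay on MCF7 cells (Homo sapiens) for cytotoxicity, read by MTT assay, with a stated time of 72 h; a lower number here means a stronger inhibitor, a higher number a weaker inhibitor:
compound 1, `CCCCCCSC(=S)N[C@H]1CCOC1=O`: > 128000 nM
compound 2, `CCCCCCCCSC(=S)N[C@H]1CCOC1=O`: > 128000 nM

In this assay compound 1 reaches only the limit of > 128000 nM, not a number. Compound 2 likewise stops at the limit of > 128000 nM. Going by the values given here, the one measured step, a step that the two limits leave unreadable from compound 1 to compound 2, is therefore unreadable in size and direction; both values sit at the limit of > 128000 nM in this assay, at which 2 of the 2 values shown sit. Compound 2 thus stands at a limit only, with nothing to rank it against compound 1.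

Compound 3, `CCCCCCCCCCCCSC(=S)N[C@H]1CCOC1=O`, differs from compound 2 by butyl in place of hydrogen on a saturated chain carbon, eight bonds along the chain from a sulfur. The sole step at hand, from compound 1 to compound 2, gives no readable size, so the measured pair yields neither size nor direction for the step to compound 3 in this assay; no move beyond the scatter can be supported from the numbers shown. Compound 3 is expected to give about 150000 nM, within 40000 nM to 500000 nM. The expected step, a step that the limit leaves unreadable from compound 2 to compound 3, most likely still ends at the limit.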

Compound 3, half-maximal inhibitory concentration: 61100 nM
For compound 3 the middle estimate is 2.5-fold (0.39 log units) above the measured one; measured number inside the range.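

In this assay this position now gives a readable result: butyl in place of hydrogen on a saturated chain carbon, eight bonds along the chain from a sulfur, brings an at least 2.0-fold lower number from compound 2 to compound 3 (0.32 log units; beyond the scatter). A still larger difference in chain length brings an at least 2.0-fold lower number from compound 1 to compound 3 (0.32 log units; beyond the scatter), so lengthening the chain has a visible effect here, which the unreadable step between compound 1 and compound 2 could not show. Both steps give only a minimum size, since each starts from a limit and not from a number: the limit of > 128000 nM in this assay, at which 2 of the 3 values shown sit.

On these data alone, whether a chain longer than that of compound 3 lowers the number further stays open. Also open, as far as these compounds go, is whether an amine or a carboxylic acid in place of the butyl would keep the step.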